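The source may hold more compounds than are shown below. What is called first, only, known or untested is meant among the compounds shown, and "the series" means these compounds.

Measured compounds:
compound 1 `CC1=C(CCC(=O)OCCCCOc2no[n+]([O-])c2S(=O)(=O)c2ccccc2)C(=O)c2c(O)cccc2C1=O`: 3330 nM
compound 2 `CC1=C(CCCC(=O)OCCOc2no[n+]([O-])c2S(=O)(=O)c2ccccc2)C(=O)c2c(O)cccc2C1=O`: 4160 nM

In a functional assay on HepG2 cells (Homo sapiens) for inhibition, read by MTT assay, with a stated time of 72 h (on this read-out higher numbers stand for weaker inhibition and lower numbers for stronger inhibition), compound 1 gives 3330 nM and compound 2 gives 4160 nM. Compound 1 carries the lower of the two numbers, but its gap to compound 2 lies within the usual scatter, so the pair cannot be ranked. Compound 3 `CC1=C(C(C)CC(=O)OCCCCOc2no[n+]([O-])c2S(=O)(=O)c2ccccc2)C(=O)c2c(O)cccc2C1=O` is not yet measured; it differs from compound 1 by methyl in place of hydrogen on a saturated chain carbon bound to a double-bonded ring carbon and a saturated chain carbon. For the measured compounds named here, no step between measured compounds shows what this change does. A methyl in place of hydrogen is expected to leave the value near that of compound 1, with an expected step of a 1.1-fold higher number from compound 1 to compound 3 (0.03 log units; within the scatter) that stays inside the scatter. Compound 3 is therefore estimated at 3600 nM, within 1500 nM to 8500 nM.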

Compound 3, half-maximal inhibitory concentration: 4240 nM
Compound 3: middle estimate off by 1.2-fold (0.07 log units), on the low side; low and high end bracket the measured number.
By their numbers in this assay, from the lowest: compounds 1, 2 and 3 (each within the scatter of the next).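

In this assay, for the compounds shown here, methyl in place of hydrogen on this saturated chain carbon gives a 1.3-fold higher number from compound 1 to compound 3 (0.10 log units; within the scatter), the first direct reading of any change at this place. On this read-out, compound 3 therefore cannot be told apart from compound 1, so this small addition is accommodated here. Nothing measured offers a reason for this result. On these data alone, whether a larger group such as ethyl or phenyl, or an amine or a carboxylic acid, would give a similar number at this carbon remains open.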